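Changing the Aryl Group on the Most Active Compound

This account rests on a few compounds, and the source may have more. Where it says the series, first, only, none or still open, it means among the compounds named here.

For the measured compounds named here, in a functional assay on KBVIN cells (Homo sapiens) for antiproliferative activity, read by sulforhodamine B assay, with a stated time of 3 days (a lower number here means that less compound is needed, a higher number that more compound is needed for the effect), compound 3 `CCC1=C(O)c2c(oc(-c3ccc(OC)c(C)c3)cc2=O)C(CC)(CC)C1=O` gives 0.1 uM, the lowest of the three numbers so far. Compound 1 `CCC1=C(O)c2c(oc(-c3ccccc3C)cc2=O)C(CC)(CC)C1=O` gives 2.41 uM, and compound 2 `CCC1=C(O)c2c(oc(-c3ccc(C)cc3C)cc2=O)C(CC)(CC)C1=O` gives 8.52 uM. Compound 4 `CCC1=C(O)c2c(oc(-c3cc(C)cc(C)c3)cc2=O)C(CC)(CC)C1=O` has 3,5-dimethylphenyl in place of 4-methoxy-3-methylphenyl on the shared core (3,5-dimethylphenyl in place of 4-methoxy-3-methylphenyl on an aromatic carbon). Going by the values given here, no measured step makes this exact swap. The closest guides are the large steps that introduce 4-methoxy-3-methylphenyl, a 24-fold lower number from compound 1 to compound 3 (1.38 log units; beyond the scatter) and an 85-fold lower number from compound 2 to compound 3 (1.93 log units; beyond the scatter). The modest 3.5-fold higher number from compound 1 to compound 2 (0.55 log units; beyond the scatter) shows that one added methyl can also shift this assay. Removing that group is therefore expected to raise the number substantially, though perhaps less than those large steps. The expected change is a 9.0-fold higher number from compound 3 to compound 4 (0.95 log units; beyond the scatter). Compound 4 is estimated at 0.9 uM, with a range of 0.18 uM to 4.5 uM.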

Compound 4, concentration for half-maximal effect: 0.45 uM
Compound 4: middle estimate off by 2.0-fold (0.30 log units), on the high side, and the stated range covers the measured number.
By their numbers in this assay, from the lowest: compound 3; then compound 4; then compound 1; then compound 2.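

Replacing 4-methoxy-3-methylphenyl with 3,5-dimethylphenyl in this assay gives a 4.5-fold higher number from compound 3 to compound 4 (0.65 log units; beyond the scatter), so a low number here does not depend on the methoxy group, although compound 3 keeps the lowest number. The arrangement of the methyl groups matters: 3,5-dimethylphenyl in place of 2,4-dimethylphenyl gives a 19-fold lower number from compound 2 to compound 4 (1.28 log units; beyond the scatter). Replacing 2-methylphenyl with 3,5-dimethylphenyl gives a 5.4-fold lower number from compound 1 to compound 4 (0.73 log units; beyond the scatter).

Nothing available explains these differences. From the compounds shown here alone, it remains open how a 3,5-dimethoxyphenyl group, or an amine on this aromatic ring, would compare.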